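From Fluoro to Chloro on the Aromatic Ring

A few compounds are considered here, and "the series" means these few. Any claim that something is new, unique, unknown or untested is made for them only; others in the source may bear on it.

Compound 1, `CC1(C)Cc2c(OCc3ccccc3)ccc(C(=O)/C=C/c3ccccc3)c2O1`, was tested in a functional assay on B16 cells (Mus musculus) for antiproliferative activity, read by MTT assay, with a stated time of 48 h (a lower number here means a stronger inhibitor, a higher number a weaker inhibitor), where compound 1 gives 30300 nM. Compound 2, `CC1(C)Cc2c(OCc3ccccc3)ccc(C(=O)/C=C/c3ccc(F)cc3)c2O1`, carries a fluoro in place of a hydrogen on an aromatic carbon. In this assay compound 2 reaches only a limit of the assay, > 100000 nM, so its true number is not known. The measured step is an at least 3.3-fold higher number from compound 1 to compound 2 (0.51 log units; beyond the scatter). Compound 2 thus stands at the limit of > 100000 nM in this assay, at which 1 of the 2 values shown sits, the weaker end of what has been seen so far.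

Compound 3, `CC1(C)Cc2c(OCc3ccccc3)ccc(C(=O)/C=C/c3ccc(Cl)cc3)c2O1`, differs from compound 2 by chloro in place of fluoro on an aromatic carbon. For the measured compounds named here, only one measured step bears on this position: an at least 3.3-fold higher number from compound 1 to compound 2 (0.51 log units; beyond the scatter) shows that putting a halogen there raised the number, at least modestly. Nothing measured here tells how chloro compares with fluoro at that site, so the expectation stays near compound 2. Compound 3 is therefore expected to remain a weak inhibitor in this assay, and the expected step of a number no higher from compound 2 to compound 3 (the limit leaves the size open) means no change beyond the scatter. The estimate for compound 3 is 100000 nM, within a range from 30000 nM to 300000 nM, and this assay may well again report only a limit.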

Compound 3, half-maximal inhibitory concentration: > 100000 nM
Compound 3: a limit, no number; the forecaster's own chance of this, stated with the estimate: 60%; the middle value sits exactly at the limit.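

In this assay, chloro in place of hydrogen gives an at least 3.3-fold higher number from compound 1 to compound 3 (0.51 log units; beyond the scatter), so the loss of activity seen with fluoro in an at least 3.3-fold higher number from compound 1 to compound 2 (0.51 log units; beyond the scatter) is not unique to that one halogen. Among the three compounds, hydrogen at this place, para to a large group, is the only case with a measured number, and both halogens push the reading in the same direction. The step from fluoro to chloro itself cannot be read, and the readings for the two halogen compounds end at one shared limit: the limit of > 100000 nM in this assay, at which 2 of the 3 values shown sit.

As far as these compounds go, how far compound 2 and compound 3 truly lie past that limit remains open, and with it whether fluoro and chloro differ at all at this place. Also open, from the compounds shown here alone, is whether a group of another kind here, such as methoxy, an amine or a carboxylic acid, would weaken the compound in the same way or bring the number below that of compound 1.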